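The source may report more compounds than this note shows. Statements on the series, on what has been measured and on what is new or still open speak of the compounds shown alone.

Of the compounds shown here, three sharing one core have been tested in an in vitro ADME assay on microsomes (Mus musculus) for metabolic stability (a lower number here means that the compound disappears faster, a higher number that the compound lasts longer), and they differ in the group on an aromatic nitrogen. Compound 1 `CNC(=O)Nc1ccc(-c2nc(N3CC4CCC(C3)O4)c3cnn(C)c3n2)cc1`, with methyl there, gives > 0.5 h, which is a limit of the assay and not a number. Compound 2 `CNC(=O)Nc1ccc(-c2nc(N3CC4CCC(C3)O4)c3cnn(CCN(C)C)c3n2)cc1`, with 2-(dimethylamino)ethyl, gives 0.0833 h. Compound 3 `CNC(=O)Nc1ccc(-c2nc(N3CC4CCC(C3)O4)c3cnn([C@H]4CC[C@@H](O)CC4)c3n2)cc1`, with 4-hydroxycyclohexyl, gives > 0.5 h, again a limit and not a number. Compound 3 thus stands at the limit of > 0.5 h in this assay, at which 2 of the 3 values shown sit.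

Compound 4 `CNC(=O)Nc1ccc(-c2nc(N3CC4CCC(C3)O4)c3cnn(C4CCC5(CC4)OCCCO5)c3n2)cc1` carries a group of 11 heavy atoms (9 carbon, 2 oxygen; one six-membered non-aromatic ring of carbon only, one six-membered non-aromatic ring with 2 hetero atoms) in place of a group of 7 heavy atoms (6 carbon, 1 oxygen; one six-membered non-aromatic ring of carbon only), on an aromatic nitrogen. Among the compounds with values here, no measured step brings in a group like this one. The closest step is a step that the two limits leave unreadable from compound 1 to compound 3, which gives no size. The readable steps are an at least 6.0-fold lower number from compound 1 to compound 2 (0.77 log units; beyond the scatter) and an at least 6.0-fold higher number from compound 2 to compound 3 (0.77 log units; beyond the scatter), and both involve compound 2 alone. The entering group, like the one leaving, has no net charge, so compound 3 is the nearer guide.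

The estimated change, small and with no clear direction, is a number no higher from compound 3 to compound 4 (the limit leaves the size open). Compound 4 is expected at 0.5 h, with an estimated range from 0.2 h to 1 h.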

Compound 4, half-life: > 0.5 h
Compound 4 gave a limit, no number; the forecaster's own chance of this, stated with the estimate: 55%; the middle value lies on the limit itself.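

In this assay compound 4 gives > 0.5 h, which is a limit of the assay and not a number. The step to this larger group, which has no hydrogen-bond donor, is an at least 6.0-fold higher number from compound 2 to compound 4 (0.77 log units; beyond the scatter), a second readable step of this kind, while the steps among compound 1, compound 3 and compound 4 cannot be read. On this aromatic nitrogen, methyl, 4-hydroxycyclohexyl and now the larger group all end at one limit, and only compound 2, with 2-(dimethylamino)ethyl, goes against this: the limit of > 0.5 h in this assay, at which 3 of the 4 values shown sit.

Going by these compounds, how far compound 1, compound 3 and compound 4 lie beyond that limit stays open, and with it whether these groups differ at all. Also open, on these data alone, is whether the low number of compound 2 goes with its amine, which a neutral chain such as 2-methoxyethyl on the same nitrogen could test.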